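This account rests on a few compounds, and the source may have more. Where it says the series, first, only, none or still open, it means among the compounds named here.

Of the compounds shown here, three built on one shared core have been measured in a functional assay on NCI-H460 cells (Homo sapiens) for antiproliferative activity, read by MTT assay, with a stated time of 72 h; on this read-out lower numbers stand for stronger inhibition and higher numbers for weaker inhibition. Compound 1 `Cn1ncnc1-c1cc(Oc2ccc(NC(=O)Nc3cccc(C(F)(F)F)c3)cc2F)ccn1` gives 11600 nM in this assay. Compound 3 `CCN(CC)CCn1cnnc1-c1cc(Oc2ccc(NC(=O)Nc3ccc(Cl)cc3Cl)cc2F)ccn1` gives 5380 nM. Compound 2 `CCN(CC)CCn1cnnc1-c1cc(Oc2ccc(NC(=O)Nc3ccccc3C(F)(F)F)cc2F)ccn1` reaches only the limit of > 50000 nM, and for it no number is known. Of the two numbers, compound 1 holds the higher one, and its gap to compound 3 lies beyond the usual scatter. Going by the values given here, the only step between compounds differing in one place is an at least 9.2-fold lower number from compound 2 to compound 3 (0.96 log units; beyond the scatter); this step concerns the group on the amide-type nitrogen and rests on the limit (the limit of > 50000 nM in this assay, at which 1 of the 3 values shown sits), which leaves its true size open.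

Compound 4 `CN(C)CCCn1cnnc1-c1cc(Oc2ccc(NC(=O)Nc3cccc(C(F)(F)F)c3)cc2F)ccn1` differs from compound 1 in 4-(3-(dimethylamino)propyl)-4H-1,2,4-triazol-3-yl in place of 1-methyl-1H-1,2,4-triazol-5-yl on an aromatic carbon. Among the compounds with values here, no measured pair differs at this place, and the single measured step changes another part of the molecule, offering no guide to direction. For compound 4 a step of a 1.4-fold lower number from compound 1 to compound 4 (0.14 log units; within the scatter) lying within the scatter is expected. Compound 4 is thus estimated at 8500 nM, with a range from 3000 nM to 25000 nM.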

Compound 4, half-maximal inhibitory concentration: 1790 nM
Estimate against measurement, compound 4: 4.7-fold (0.68 log units) above; measured number outside the range, below it.
By their numbers in this assay, from the lowest: compound 4; then compound 3; then compound 1. At a limit, above all of these: compound 2.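

Placing the 4-(3-(dimethylamino)propyl)-4H-1,2,4-triazol-3-yl group on this aromatic carbon, next to the ring nitrogen, in place of the 1-methyl-1H-1,2,4-triazol-5-yl group gives a 6.5-fold lower number from compound 1 to compound 4 (0.81 log units; beyond the scatter) in this assay and is the first readable step at this position. The earlier step concerned only the group on the amide-type nitrogen, whereas this one shows that the group at this other position can also move the number by more than the scatter. Nothing shown here accounts for the size or direction of this step.

The change alters both the attachment of the triazole and the chain it carries, so the share of each in the step stays unresolved. A plain 4-methyl-4H-1,2,4-triazol-3-yl group would separate the two, and a piperidine at the chain end or a longer chain would test how much the end of the chain matters.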